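This account rests on a few compounds, and the source may have more. Where it says the series, first, only, none or still open, it means among the compounds named here.

In a functional assay on DU-145 cells (Homo sapiens) for inhibition (on this read-out higher numbers stand for weaker inhibition and lower numbers for stronger inhibition), compound 1 `COc1ccc(Cl)cc1-c1cc(Nc2ccc(Cl)cc2)nc(N)n1` gives 500 nM and compound 2 `CCOc1ccc(Br)cc1-c1cc(Nc2ccc(C#N)cc2)nc(N)n1` gives 400 nM, two numbers within the usual scatter of each other. Compound 3 `CCOc1ccc(Br)cc1-c1cc(Nc2cccc(C#N)c2)nc(N)n1` reaches only a limit of the assay, > 1000 nM. Compound 4 `CCOc1ccc(Br)cc1-c1cc(Nc2ccc(/C(C)=N\O)cc2)nc(N)n1` differs from compound 2 at a single place: a group of 4 heavy atoms (2 carbon, 1 nitrogen, 1 oxygen; no ring) in place of a group of 2 heavy atoms (1 carbon, 1 nitrogen; no ring), on an aromatic carbon. Going by the values given here, the one measured step involving this cyano group, an at least 2.5-fold higher number from compound 2 to compound 3 (0.39 log units; beyond the scatter), puts 3-cyanophenyl in place of 4-cyanophenyl. It shows that, in this pair, the change of place matters, but not what a different group would do. Among the compounds with values here, no measured compound replaces the cyano group itself. Starting from compound 2 at 400 nM, the expected step in this assay is a 1.3-fold higher number from compound 2 to compound 4 (0.10 log units; within the scatter), none beyond the scatter, though with wide uncertainty. For compound 4 the estimated value is 500 nM, with an expected range from 150 nM to 1500 nM.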

Compound 4, half-maximal inhibitory concentration: < 50 nM
Compound 4: no number, only a limit; the forecaster's own chance of this, stated with the estimate: 25%; at least 10-fold (1.00 log units) between middle value and limit.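

Compound 4 gives < 50 nM in this assay, which is a limit of the assay and not a number. Even so, exchanging the cyano group for the larger group on this aromatic carbon, para to a large group, gives an at least 8.0-fold lower number from compound 2 to compound 4 (0.90 log units; beyond the scatter). The earlier pair only moved the cyano group, whereas this step shows that replacing it at this place can strengthen inhibition well beyond the scatter.

The compounds shown do not separate the hydrogen-bond donor of the entering group from its size. An acetyl group or a carboxylic acid at this place remains an open comparison.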